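Moving the Hydroxy Group in a Growth Inhibition Series

The compounds below may be only part of what the source reports. "The series", "measured", "known", "first", "only" and "open" are said of these compounds alone.

In a functional assay on K562 cells (Homo sapiens) for inhibition, read by fluorescence, with a stated time of 72 h (a higher number here means a weaker inhibitor of growth, a lower number a stronger inhibitor of growth), compound 3 (`CC(C)CCn1cnc2c(Nc3cccc(O)c3)nc(N[C@H]3CC[C@H](N)CC3)nc21`) gives 7600 nM. That value lies within the scatter of compound 1 (`CCCCCCn1cnc2c(Nc3ccc(O)cc3)nc(N[C@H]3CC[C@H](N)CC3)nc21`), which gives 5400 nM. It stands beyond the scatter from compound 2 (`CC(C)CCn1cnc2c(Nc3cccc(Cl)c3)nc(N[C@H]3CC[C@H](N)CC3)nc21`), which gives the lower 1500 nM.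

Compound 4 (`CC(C)CCn1cnc2c(Nc3ccc(O)cc3)nc(N[C@H]3CC[C@H](N)CC3)nc21`) has 4-hydroxyphenyl in place of 3-hydroxyphenyl on a nitrogen on an aromatic ring.

For the measured compounds named here, the only measured step at this group, a 5.1-fold higher number from compound 2 to compound 3 (0.70 log units; beyond the scatter), shows that a change there can move the number, but it exchanges one group for another and does not relocate the hydroxy. Going by the values given here, no measured step isolates that move. Compound 1 offers the nearest evidence, since it carries 4-hydroxyphenyl with a hexyl chain and gives 5400 nM. A shift beyond the scatter is therefore not expected in this assay, and the estimated step is a 1.3-fold lower number from compound 3 to compound 4 (0.10 log units; within the scatter). The estimate for compound 4 is 6000 nM, with an expected range from 2500 nM to 14000 nM.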

Compound 4, concentration for 50% growth inhibition: 4600 nM
Compound 4: the middle estimate sits 1.3-fold (0.12 log units) above what was measured, within the range that was stated.
By their numbers in this assay, from the lowest: compound 2; then compounds 4, 1 and 3 (each within the scatter of the next).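

In this assay, the hydroxy relocation gives a 1.7-fold lower number from compound 3 to compound 4 (0.22 log units; within the scatter) and so, unlike the exchange of chloro for hydroxy, stays within the scatter. The distance from compound 2 holds for both hydroxy groups, since a 3.1-fold higher number from compound 2 to compound 4 (0.49 log units; beyond the scatter) stands with the earlier 5.1-fold higher number from compound 2 to compound 3 (0.70 log units; beyond the scatter) and both lie beyond the scatter. For the compounds shown here, with 4-hydroxyphenyl held constant, the chain change gives a 1.2-fold lower number from compound 1 to compound 4 (0.07 log units; within the scatter) and thus the first direct comparison of the two chains, which this assay does not separate. Nothing on hand accounts for any of these steps.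

The compounds shown leave open how a methoxy group, an amine or a carboxylic acid on this phenyl ring would compare with hydroxy and chloro. They also leave open whether a longer chain on the aromatic nitrogen would move the number.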